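The compounds below may be only part of what the source reports. "The series", "measured", "known", "first", "only" and "open" are said of these compounds alone.

Working notes on the amide side chain, all on the shared core. In a functional assay on HCT-116 cells (Homo sapiens) for cytotoxicity, read by MTT assay, with a stated time of 72 h (a higher number here means a weaker inhibitor, a lower number a stronger inhibitor), compound 1 (`N[C@H]1CC[C@H](Nc2c(C(=O)NCc3ccco3)nc(Br)c3cccnc23)CC1`) gives > 10000 nM, which is a limit of the assay and not a number. Compound 2 (`N[C@H]1CC[C@H](Nc2c(C(=O)NCc3ccc(Cl)cc3Cl)nc(Br)c3cccnc23)CC1`) gives 6000 nM in this assay. For compound 3 (`CN(C)c1ccc(CNC(=O)c2nc(Br)c3cccnc3c2N[C@H]2CC[C@H](N)CC2)cc1`) the entry is "not determined" (no result reported), so it has no place on the numbers and no measured starting point for the next step.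

Compound 4 (`C[C@H](NC(=O)c1nc(Br)c2cccnc2c1N[C@H]1CC[C@H](N)CC1)c1ccc(F)cc1`) carries 1-(4-fluorophenyl)ethyl in place of 4-(dimethylamino)benzyl on an amide-type nitrogen.

For the measured compounds named here, the only measured step that bears on this is an at least 1.6-fold lower number from compound 1 to compound 2 (0.22 log units; that floor lies within the scatter). It swaps furan-2-yl for 2,4-dichlorophenyl on a saturated chain carbon bound to an amide-type nitrogen, so it concerns the same side of the amide. Its size is known only as a floor, and compound 3 has no number, so no size or direction can be expected for the step to compound 4 itself. Going by the values given here, the expectation therefore rests on the level of the two measured neighbours, with compound 2 at 6000 nM as the only true number. A result reported only as a limit remains quite possible. Compound 4 is expected at about 6000 nM, with an estimated range of 1500 nM to 20000 nM.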

Compound 4, half-maximal inhibitory concentration: > 10000 nM
Compound 4: only a limit was reported; the forecaster's own chance of this, stated with the estimate: 35%; middle value at least 1.6-fold (0.22 log units) away from the limit.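

In this assay compound 4 gives > 10000 nM, which is a limit of the assay and not a number. On the amide-type nitrogen, the change to 1-(4-fluorophenyl)ethyl is read as an at least 1.6-fold higher number from compound 2 to compound 4 (0.22 log units; that floor lies within the scatter); the result does not establish a real loss. 2,4-dichlorobenzyl in compound 2 remains the only side chain here with a true number, 6000 nM. Compound 1 and compound 4 both stand at one limit, so the step between them cannot be read: the limit of > 10000 nM in this assay, at which 2 of the 4 values shown sit.

The step from compound 2 to compound 4 alters both the chain carbon, which gains a methyl and a defined stereocentre, and the groups on the aromatic ring, so the two changes cannot be separated; a plain 4-fluorobenzyl on the same amide-type nitrogen would divide them. From the compounds shown here alone, the opposite stereocentre of the 1-(4-fluorophenyl)ethyl group also remains open, as does the standing of 4-(dimethylamino)benzyl in compound 3, which has no reported result.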